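A few compounds are considered here, and "the series" means these few. Any claim that something is new, unique, unknown or untested is made for them only; others in the source may bear on it.

Measured so far in an assay on adrenal medulla for inhibition of Vasopressin V2 receptor (Rattus norvegicus), read by radioligand binding; on this read-out higher numbers stand for weaker inhibition and lower numbers for stronger inhibition:
- compound 2 `CN1CCN(C(=O)CCCOc2cc(C(=O)N3CCCCc4sccc43)ccc2NC(=O)c2ccccc2-c2ccccc2)CC1`: 1 nM
- compound 1 `O=C(Nc1ccc(C(=O)N2CCCN(CCN3CCCC3)c3sccc32)cc1)c1ccccc1-c1ccccc1`: 10 nM
- compound 3 `O=C(Nc1ccc(C(=O)N2CCCCc3sccc32)cc1OCCCC(=O)N1CCC(N2CCCCC2)CC1)c1ccccc1-c1ccccc1`: 20 nM

Compound 2 stands lowest of the three numbers in this assay. Compound 1 at 10 nM is the nearer of the other two, compound 3 at 20 nM the further, and both gaps lie beyond the scatter, so compound 2 is the strongest inhibitor of this small set.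

Compound 4 `CN1CCCN(CCCOc2cc(C(=O)N3CCCCc4sccc43)ccc2NC(=O)c2ccccc2-c2ccccc2)CC1` is not yet measured. Relative to compound 2 the change is 4-methyl-1,4-diazepan-1-yl in place of (4-methylpiperazin-1-yl)carbonyl on a saturated chain carbon, three bonds along the chain from an oxygen on an aromatic ring.

Among the measured compounds shown here, only one measured step touches the same end of the chain: a 20-fold higher number from compound 2 to compound 3 (1.30 log units; beyond the scatter). That step kept the carbonyl and exchanged the ring on it, and it moved the number a long way, so this region clearly matters to the read-out. For the measured compounds named here, no measured pair tests removing the carbonyl or widening the ring, so the direction of the present step is not fixed by the data. Going by the values given here, since compound 2 holds the lowest number and the one comparable step went upward, a moderate rise beyond the scatter is expected rather than a further fall.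

Estimate for compound 4 in this assay: 5 nM, range 1 nM to 25 nM, which would mean a step of a 5.0-fold higher number from compound 2 to compound 4 (0.70 log units; beyond the scatter).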

Compound 4, half-maximal inhibitory concentration: < 1 nM
Compound 4: only a limit was reported; the forecaster's own chance of this, stated with the estimate: 2%; middle value at least 5.0-fold (0.69 log units) away from the limit.
By their numbers in this assay, from the lowest: compound 2; then compounds 1 and 3 (each within the scatter of the next).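

Replacing (4-methylpiperazin-1-yl)carbonyl with 4-methyl-1,4-diazepan-1-yl on the chain leaves the number in this assay no worse, at a number no higher from compound 2 to compound 4 (the limit leaves the size open), so a low number at this position does not depend on the carbonyl. Compound 4 gives only a limit, and its distance from the neighbouring value cannot be read because the read-out stops there: the limit of < 1 nM in this assay, at which 1 of the 4 values shown sits. This end of the chain also does not respond the same way to every exchange: with the carbonyl kept, 4-(piperidin-1-yl)piperidin-1-yl gave a 20-fold higher number from compound 2 to compound 3 (1.30 log units; beyond the scatter), while the carbonyl-free seven-membered ring brought no rise.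

From the compounds shown here alone, the step to compound 4 changes the carbonyl and the ring size together, so their separate contributions stay open; 4-methylpiperazin-1-yl set directly on the propyl chain, or (4-methyl-1,4-diazepan-1-yl)carbonyl, would separate them. Also open, going by these compounds, is whether the low number survives with an ethyl chain in place of the propyl chain, or with a carboxylic acid at the chain end in place of the ring amine.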